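Swapping the amine on the core from compound 2 to compound 4

This account rests on a few compounds, and the source may have more. Where it says the series, first, only, none or still open, it means among the compounds named here.

Among three compounds tested in a functional assay on MCF7 cells (Homo sapiens) for antiproliferative activity, read by MTT assay, with a stated time of 72 h (a higher number here means a weaker inhibitor, a lower number a stronger inhibitor), compound 2 `Cc1cc(N2CCN(C(C)C)CC2)nc2ccc(NC(=O)c3ccc(Cl)c(Cl)c3)cc12` gives the lowest number, 1710 nM. Among the measured compounds shown here, compound 3 `CCN1CCN(c2cc(C)c3cc(NC(=O)c4ccc(F)cc4)ccc3n2)CC1` gives 4030 nM, and compound 1 `CCc1ccccc1C(=O)Nc1ccc2nc(N3CCN(CC)CC3)cc(C)c2c1` gives 15800 nM; the only measured step, a 3.9-fold lower number from compound 1 to compound 3 (0.59 log units; beyond the scatter), concerns the amide side of the core. Compound 4 `Cc1cc(NCCN2CCCCC2)nc2ccc(NC(=O)c3ccc(Cl)c(Cl)c3)cc12` differs from compound 2 elsewhere: (2-(piperidin-1-yl)ethyl)amino in place of 4-isopropylpiperazin-1-yl on an aromatic carbon. For the measured compounds named here, no measured step touches this part of the core, so there is no direct guide, and the change keeps the same atoms while adding a hydrogen-bond donor. The expected step is a 1.3-fold higher number from compound 2 to compound 4 (0.11 log units; within the scatter), which is small. Compound 4 is therefore estimated at 2200 nM in this assay, within a range from 700 nM to 7000 nM.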

Compound 4, half-maximal inhibitory concentration: 1190 nM
Beside the measured number, compound 4's estimate is 1.8-fold (0.27 log units) above it; the measured number falls inside the stated range.
By their numbers in this assay, from the lowest: compounds 4 and 2 (each within the scatter of the next); then compound 3; then compound 1.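

In this assay, among the compounds shown here, the first measured change at this amine position is a 1.4-fold lower number from compound 2 to compound 4 (0.16 log units; within the scatter), with the amide side of the core held constant. At least for this pair, replacing 4-isopropylpiperazin-1-yl with (2-(piperidin-1-yl)ethyl)amino adds a hydrogen-bond donor and moves the ring onto a chain, yet leaves the number within the scatter. The data offer no explanation for this result. Still open, as far as these compounds go, is whether a longer chain or a morpholine ring in place of piperidine would shift the number. From the compounds shown here alone, whether the same swap behaves alike with other amide groups also remains open.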